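The compounds below may be only part of what the source reports. "The series", "measured", "known", "first", "only" and "open" are said of these compounds alone.

Three 2,6-dibenzylidenecyclohexanones carrying a nitro group were examined in a functional assay on CCRF-CEM cells (Homo sapiens) for cytotoxicity, with a stated time of 72 h; on this read-out higher numbers stand for weaker inhibition and lower numbers for stronger inhibition. Compound 1 `O=C1/C(=C/c2ccccc2)CCC/C1=C\c1cccc([N+](=O)[O-])c1` gives 2290 nM in this assay. Compound 2 `O=C1/C(=C/c2ccccc2)CCC/C1=C\c1ccc([N+](=O)[O-])cc1` gives 9320 nM; how the core of compound 2 differs from that of compound 1 is not broken down here, and the two values simply show compound 2 with the higher number. Compound 3 `COc1ccc(/C=C2\CCC/C(=C\c3cccc([N+](=O)[O-])c3)C2=O)cc1` gives 8220 nM, a value that sits close to that of compound 2. Compound 3 arises from compound 1 by methoxy in place of hydrogen on an aromatic carbon, and this change produced a 3.6-fold higher number from compound 1 to compound 3 (0.56 log units; beyond the scatter). Compound 4 `COc1ccc(/C=C2\CCC/C(=C\c3ccc([N+](=O)[O-])cc3)C2=O)cc1` is the unmeasured member; it arises from compound 2 by the same change, (methoxy in place of hydrogen on an aromatic carbon), and the same change occurs twice across these four compounds. Going by the values given here, because compound 1 to compound 3 gave a 3.6-fold higher number from compound 1 to compound 3 (0.56 log units; beyond the scatter), the step from compound 2 to compound 4 is expected to be a 2.4-fold higher number from compound 2 to compound 4 (0.37 log units; beyond the scatter), though with only one prior example the size rests on thin ground. On that basis compound 4 is estimated to give 22000 nM in this assay, with a range of 8000 nM to 55000 nM.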

Compound 4, half-maximal inhibitory concentration in the CCRF-CEM assay: 250000 nM
For compound 4 the middle estimate is 11-fold (1.06 log units) below the measured one; the whole stated range lies below it.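

In the CCRF-CEM assay compound 4 gives 250000 nM. In the CCRF-CEM assay, methoxy in place of hydrogen on an aromatic carbon gave a 27-fold higher number from compound 2 to compound 4 (1.43 log units; beyond the scatter), so the number rose on both cores, but the size of the step did not carry over from one core to the other: the same change on two cores in the CCRF-CEM assay, a 3.6-fold higher number (0.56 log units; beyond the scatter) from compound 1 to compound 3 and a 27-fold higher number (1.43 log units; beyond the scatter) from compound 2 to compound 4, 7.5-fold (0.87 log units) apart, beyond the scatter of two such steps These two pairs show a shared direction and a core-dependent size; they give no rule for other cores and do not tell what in the cores sets the two steps apart. In a physicochemical assay for lipophilicity (on this read-out lower numbers stand for lower lipophilicity and higher numbers for higher lipophilicity), compound 2 gives 5.08 and compound 4 gives 5.08. In the physicochemical assay the same change shows no change at the digits printed from compound 2 to compound 4 (within the scatter), so that read-out offers no parallel to the large step seen in cytotoxicity.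

Going by these compounds, it remains open whether the gap between the two steps would persist for other groups placed on the same aromatic carbon, such as an amine, a hydroxyl or a longer ether chain like ethoxy. Going by these compounds alone, with only two pairs, it also remains open how large the step would be on any further core.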